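This account rests on a few compounds, and the source may have more. Where it says the series, first, only, none or still open, it means among the compounds named here.

Compound 1 `O=C1O[C@H]([C@@H](O)Cn2cc(-c3ccc(Br)cc3)nn2)C(OCc2ccccc2)=C1OCc1ccccc1`: 750 nM
Compound 2 `Cc1ccc(-c2cn(C/C=C3\OC(=O)C(OCc4ccccc4)=C3OCc3ccccc3)nn2)cc1`: > 100000 nM
Compound 3 `CCCCCc1ccc(-c2cn(C[C@H](O)[C@H]3OC(=O)C(OCc4ccccc4)=C3OCc3ccccc3)nn2)cc1`: 6220 nM

All three were tested in a functional assay on A549 cells (Homo sapiens) for antiproliferative activity, read by MTT assay, with a stated time of 72 h; a higher number here means a weaker inhibitor, a lower number a stronger inhibitor. Compound 2 sits at the limit of > 100000 nM in this assay, at which 1 of the 3 values shown sits, so for compound 2 only a limit is known, not a number. Compound 4 `COc1ccc(-c2cn(C/C=C3\OC(=O)C(OCc4ccccc4)=C3OCc3ccccc3)nn2)cc1` is the next compound to be measured; it differs from compound 2 in one place, (methoxy in place of methyl on an aromatic carbon). Among the measured compounds shown here, only one measured step bears on a change of the substituent on that aromatic ring: an 8.3-fold higher number from compound 1 to compound 3 (0.92 log units; beyond the scatter). That step concerns a different pair of groups and sits on the core of compound 1, which is not the core of compound 2, and even so its size was modest. For the measured compounds named here, nothing among the measured compounds suggests that swapping methyl for methoxy would lift a compound from the limit into the measurable range. Compound 4 is therefore expected to stay at or near the limit, with an estimate of 150000 nM and a range from 50000 nM to 500000 nM. The step this estimate implies, a step that the limit leaves unreadable from compound 2 to compound 4, is expected to be nothing beyond the scatter.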

Compound 4, half-maximal inhibitory concentration: > 100000 nM
Compound 4: only a limit was reported; the forecaster's own chance of this, stated with the estimate: 80%; the middle value is on the limit's open side.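

Compound 2 and compound 4 differ only by methoxy in place of methyl, yet no step can be read between them, because each gives only a limit and not a number: the limit of > 100000 nM in this assay, at which 2 of the 4 values shown sit.

The compounds shown leave open whether any group at that place on their shared core would give a measurable value.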